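A Longer Ether Chain on the Shared Core

A few compounds are considered here, and "the series" means these few. Any claim that something is new, unique, unknown or untested is made for them only; others in the source may bear on it.

Among the compounds with values here, compound 1 `CCCOc1cccc2ccc(N)nc12` is the only compound here with a plain number: in an assay on cells with melanin-concentrating hormone receptor 1 (Homo sapiens) as the target, read by radioligand binding (a higher number here means a weaker inhibitor, a lower number a stronger inhibitor), compound 1 gives 1100 nM. Compound 2 `CC(CC(C)(C)C)Oc1cccc2ccc(N(C)C)nc12` reaches only a limit in this assay, > 2000 nM, which is not a number; (the limit of > 2000 nM in this assay, at which 1 of the 2 values shown sits). Compound 3 `CCOCC(C)Oc1cccc2ccc(N)nc12` has not yet been measured. It differs from compound 1 in one place: a group of 6 heavy atoms (5 carbon, 1 oxygen; no ring) in place of a group of 3 heavy atoms (3 carbon; no ring), on an oxygen on an aromatic ring. Within the data shown here, no measured pair shows a comparable change. The step in this assay is expected to stay close to the scatter, estimated as a 1.4-fold higher number from compound 1 to compound 3 (0.13 log units; within the scatter). Compound 3 is expected to give about 1500 nM, between 500 nM and 5000 nM.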

Compound 3, half-maximal inhibitory concentration: 1070 nM
Beside the measured number, compound 3's estimate is 1.4-fold (0.15 log units) above it; the range from low to high includes it.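

At the oxygen on an aromatic ring, this assay shows a 1.0-fold lower number from compound 1 to compound 3 (0.01 log units; within the scatter) when the propyl group gives way to a larger group that carries a hydrogen-bond acceptor. Within the data shown here, this is the first step that can be read at this place, and in this pair the added heavy atoms and acceptor leave the number within the scatter.

Nothing in the data at hand explains this result. On these data alone, whether an amine or a carboxylic acid in this place would move the number beyond the scatter stays open.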